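From ethyl to isopropyl on one amide chain

The source may report more compounds than this note shows. Statements on the series, on what has been measured and on what is new or still open speak of the compounds shown alone.

Compound 1 `CCNC(=O)c1cc(C(=O)NC)c(=O)n(Cc2ccccc2)c1`: >= 144 ug/mL (a limit)
Compound 2 `CNC(=O)c1cc(C(=O)NC2CC2)cn(Cc2cccc(F)c2)c1=O`: >= 133 ug/mL (a limit)
Compound 3 `CNC(=O)c1cc(C(=O)NC2CC2)cn(Cc2cccc3[nH]ccc23)c1=O`: 78 ug/mL

In a physicochemical assay for solubility (on this read-out lower numbers stand for lower solubility and higher numbers for higher solubility), compound 1 stands at the limit of >= 144 ug/mL in this assay, at which 1 of the 3 values shown sits. That is a limit and not a number. Compound 2 likewise stands at the limit of >= 133 ug/mL in this assay, at which 1 of the 3 values shown sits. Only compound 3 has a true number, so the starting point for this step is known only as a limit.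

Compound 4 `CNC(=O)c1cc(C(=O)NC(C)C)cn(Cc2ccccc2)c1=O` differs from compound 1 by one small edit: methyl in place of hydrogen on a saturated chain carbon bound to an amide-type nitrogen and a saturated chain carbon In words, this is methyl in place of hydrogen on a saturated chain carbon bound to an amide-type nitrogen and a saturated chain carbon, so ethylcarbamoyl becomes isopropylcarbamoyl.

Going by the values given here, the only measured step is an at least 1.7-fold lower number from compound 2 to compound 3 (0.23 log units; that floor lies within the scatter). Among the compounds with values here, it concerns a different group, so it bears on this edit only loosely, and no measured step touches the ethyl chain itself. With so little to go on, no step beyond the scatter is expected in this assay. The expected step is an at least 1.2-fold lower number from compound 1 to compound 4 (0.07 log units; that floor lies within the scatter). For compound 4 the estimated value is 120 ug/mL, with an expected range of 50 ug/mL to 170 ug/mL.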

Compound 4, solubility: >= 136 ug/mL
Compound 4 was reported as a limit (the forecaster's own chance of this, stated with the estimate: 50%); middle value at least 1.1-fold (0.05 log units) from the limit.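

Compound 1 and compound 4 both stand only as limits in this assay, not as true numbers, so no step can be read from one to the other. The compounds shown leave open whether going from ethylcarbamoyl to isopropylcarbamoyl shifts the read-out of this assay at all, and if so, in which direction.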